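Swapping a cyclopentyloxy group for a cyclopropylamide

A few compounds are considered here, and "the series" means these few. Any claim that something is new, unique, unknown or untested is made for them only; others in the source may bear on it.

Measured so far:
compound 1 `O=C(Nc1nc(-c2cccc(F)c2)cs1)c1ccc([N+](=O)[O-])o1`, 14.8 ug/mL
compound 2 `O=C(Nc1nc(-c2cccc(OC3CCCC3)c2)cs1)c1ccc([N+](=O)[O-])o1`, 0.027 ug/mL

In a physicochemical assay for solubility, read by HPLC, with a stated time of 30 min (on this read-out higher numbers stand for higher solubility and lower numbers for lower solubility), compound 2 gives 0.027 ug/mL, the lowest of the two numbers; its nearest neighbour is compound 1, which gives 14.8 ug/mL. Within the data shown here, the single measured step, a 550-fold lower number from compound 1 to compound 2 (2.74 log units; beyond the scatter), is large. Compound 3 `O=C(Nc1nc(-c2cccc(NC(=O)C3CC3)c2)cs1)c1ccc([N+](=O)[O-])o1` differs from compound 2 in one place: (cyclopropylcarbonyl)amino in place of cyclopentyloxy on an aromatic carbon. Among the measured compounds shown here, this removes the very group whose arrival brought the drop from compound 1 to compound 2, while adding a different group of the same size; no step with a cyclopropylcarbonylamino group has been measured, so the expectation rests on the one step alone. Compound 3 is therefore expected to give a higher number than compound 2 in this assay, estimated as a 37-fold higher number from compound 2 to compound 3 (1.57 log units; beyond the scatter). The estimate for compound 3 is 1 ug/mL, with a range from 0.1 ug/mL to 10 ug/mL.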

Compound 3, solubility: 0.47 ug/mL
Beside the measured number, compound 3's estimate is 2.1-fold (0.33 log units) above it; the measured number falls inside the stated range.
By their numbers in this assay, from the lowest: compound 2; then compound 3; then compound 1.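

In this assay, the change of (cyclopropylcarbonyl)amino in place of cyclopentyloxy gives a 17-fold higher number from compound 2 to compound 3 (1.24 log units; beyond the scatter), even though the group leaving and the group entering have the same count of heavy atoms, so the heavy-atom count at this aromatic carbon does not set the number on its own. The recovery is only partial, as fluoro replaced by (cyclopropylcarbonyl)amino still gives a 31-fold lower number from compound 1 to compound 3 (1.50 log units; beyond the scatter), which leaves the fluoro group with the highest number of the three. Nothing available here explains either step.

Going by these compounds, the change swaps the ring, the linking atom and the carbonyl all at once, so which of these matters remains open. An acetylamino group or a cyclopentylamino group on the same aromatic carbon could begin to separate them.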